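The source may hold more compounds than are shown below. What is called first, only, known or untested is meant among the compounds shown, and "the series" means these compounds.

In an assay on isolated protein (strain Sprague-Dawley) for inhibition of Amine oxidase [flavin-containing] B (Rattus norvegicus), read by spectrophotometry, with a stated time of 5 min (on this read-out higher numbers stand for weaker inhibition and lower numbers for stronger inhibition), compound 1 `CC(C)Oc1cc(=O)oc2cc(OCc3cccc(Cl)c3)ccc12` gives 24500 nM. In this assay, going by the values given here, compound 2 `CC(=O)COc1cc(=O)oc2cc(OCc3cccc(Cl)c3)ccc12` gives 26.9 nM, the lowest of the two numbers so far, set apart from compound 1 by a 910-fold lower number from compound 1 to compound 2 (2.96 log units; beyond the scatter). Compound 3 `CCOC(=O)COc1cc(=O)oc2cc(OCc3cccc(Cl)c3)ccc12` is yet to be measured; it carries ethoxy in place of methyl on a carbonyl carbon. Among the compounds with values here, only the step of a 910-fold lower number from compound 1 to compound 2 (2.96 log units; beyond the scatter) touches this part of the molecule, and it turned on the carbonyl, which compound 3 keeps; no measured step tests the ethoxy itself. The expectation for this assay is therefore a step within the scatter or a modest rise. Compound 3 is estimated at 60 nM (range 15 nM to 300 nM). The step expected from this estimate is a 2.2-fold higher number from compound 2 to compound 3 (0.35 log units; beyond the scatter).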

Compound 3, half-maximal inhibitory concentration: 1820 nM
Estimate against measurement, compound 3: 30-fold (1.48 log units) below; the measured number lies above the stated range.
By their numbers in this assay, from the lowest: compound 2; then compound 3; then compound 1.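

In this assay, keeping the carbonyl does not by itself keep the low number: ethoxy in place of methyl on the carbonyl carbon costs most of the gain (a 68-fold higher number from compound 2 to compound 3 (1.83 log units; beyond the scatter)). The group on that carbonyl carbon therefore strongly affects the read-out, although (ethoxycarbonyl)methyl still stands clear of isopropyl on the oxygen (a 13-fold lower number from compound 1 to compound 3 (1.13 log units; beyond the scatter)). No measurement at hand explains this loss.

Still open, going by these compounds, is whether a carboxylic acid, an amine or a methoxy on that carbonyl carbon would read nearer compound 2 or compound 3. A longer chain in place of the methyl of compound 2 would show whether the ketone tolerates any added bulk.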